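The compounds below may be only part of what the source reports. "The series", "measured", "known", "first", "only" and "open" are said of these compounds alone.

Compound 1, `Nc1nc(-c2ccccn2)nn1-c1ncnc2ccccc12`, in an assay on MCF7 cells for inhibition of Serine-protein kinase ATM (Homo sapiens), read by immunofluorescence, with a stated time of 1 h; on this read-out lower numbers stand for stronger inhibition and higher numbers for weaker inhibition: > 40000 nM, a limit of the assay rather than a number.
Compound 2, `COc1ccc2ncnc(-n3nc(-c4ccccn4)nc3N)c2c1`: 16900 nM.
Compound 3, `COc1cc2ncnc(-n3nc(-c4ccccc4)nc3N)c2cc1OC`: 2000 nM.

Among the compounds with values here, of the two numbers recorded, compound 2 stands highest; compound 3 gives a lower number, a gap beyond the scatter, though it differs at two places and so yields no single step. Compound 4, `COc1cc2c(-n3nc(-c4ccccn4)nc3N)ncnc2cc1OCc1ccccc1`, is unmeasured and differs from compound 2 by benzyloxy in place of hydrogen on an aromatic carbon. Within the data shown here, the one measured step that bears on this is an at least 2.3-fold lower number from compound 1 to compound 2 (0.37 log units; beyond the scatter), whose size is left open by the limit of > 40000 nM in this assay, at which 1 of the 3 values shown sits. A second ether substituent on the same ring of compound 2 is therefore expected to lower the number again, about a 4.8-fold lower number from compound 2 to compound 4 (0.68 log units; beyond the scatter). Compound 4 is estimated at 3500 nM, within 800 nM to 14000 nM.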

Compound 4, half-maximal inhibitory concentration: > 40000 nM
Compound 4 was reported as a limit; the forecaster's own chance of this, stated with the estimate: 5%; middle value at least 11-fold (1.05 log units) away from the limit.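

In this assay, benzyloxy in place of hydrogen on this aromatic carbon, ortho to a methoxy group, gives an at least 2.3-fold higher number from compound 2 to compound 4 (0.37 log units; beyond the scatter), whereas methoxy in place of hydrogen gave an at least 2.3-fold lower number from compound 1 to compound 2 (0.37 log units; beyond the scatter). The lower number that came with the first ether is therefore not repeated when benzyloxy enters at this position. The full size of the new step cannot be read, since compound 4 gives a limit and not a number: the limit of > 40000 nM in this assay, at which 2 of the 4 values shown sit.

As far as these compounds go, whether an amine or a carboxylic acid on this carbon would lower the number of compound 2 remains open.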